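This account rests on a few compounds, and the source may have more. Where it says the series, first, only, none or still open, it means among the compounds named here.

The study concerns three thioureas measured in an ADME assay on MT4 cells (Homo sapiens) for cytotoxicity (a lower number here means that less compound is tolerated, a higher number that more compound is tolerated), and a fourth compound that has not yet been measured there. Compound 1 `FC(F)(F)c1cccc(NC(=S)Nc2cccc(Br)c2)c1` gives 9200 nM, compound 2 `C=C(C)CNC(=S)Nc1cccc(C(F)(F)F)c1` gives 43000 nM, and compound 3 `FC(F)(F)c1cccc(NC(=S)Nc2ccc(I)cc2)c1` gives 10000 nM in this assay. Compound 3 thus holds the second highest of the three numbers; its nearest neighbour is compound 1, as the step of a 1.1-fold higher number from compound 1 to compound 3 (0.04 log units; within the scatter) shows, and its furthest is compound 2, as the step of a 4.3-fold lower number from compound 2 to compound 3 (0.63 log units; beyond the scatter) shows. Compound 4 `O=[N+]([O-])c1ccc(NC(=S)Nc2cccc(C(F)(F)F)c2)cc1` differs from compound 3 in one place: nitro in place of iodo on an aromatic carbon. The measured steps that bear on this change are the swap of one substituted phenyl for another, a 1.1-fold higher number from compound 1 to compound 3 (0.04 log units; within the scatter), and the two swaps between a substituted phenyl and a 2-methylprop-2-en-1-yl group, a 4.7-fold higher number from compound 1 to compound 2 (0.67 log units; beyond the scatter) and a 4.3-fold lower number from compound 2 to compound 3 (0.63 log units; beyond the scatter). Only the exchange of an aryl group for the alkyl group moved the number beyond the scatter, whereas the exchange of one substituted phenyl for another did not. The change from compound 3 to compound 4 keeps the phenyl group and alters only its substituent. Since a 1.1-fold higher number from compound 1 to compound 3 (0.04 log units; within the scatter) stayed within the scatter, the step expected for compound 4 is no change at the digits printed from compound 3 to compound 4 (within the scatter), that is, none beyond the scatter. Compound 4 is therefore estimated at 10000 nM in this assay, with a range from 4000 nM to 25000 nM.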

Compound 4, half-maximal cytotoxic concentration: 9200 nM
For compound 4 the middle estimate is 1.1-fold (0.04 log units) above the measured one; the range from low to high includes it.
By their numbers in this assay, from the lowest: compounds 1, 4 and 3 (each within the scatter of the next); then compound 2.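

In this assay, going by these compounds alone, the step of a 1.1-fold lower number from compound 3 to compound 4 (0.04 log units; within the scatter) is the first in this set to alter only the substituent at one fixed place, on an aromatic carbon para to a large group, whereas the earlier step between compound 1 and compound 3 exchanged 3-bromophenyl for 4-iodophenyl and so changed both the halogen and where it sits. The change here is a marked one in what is counted, since iodo, a single heavy atom with no hydrogen-bond acceptors, gives way to nitro, with three heavy atoms and two hydrogen-bond acceptors, yet the number stays within the scatter, so among the aryl thioureas compound 1, compound 3 and compound 4 the substituent has so far made no readable difference, and only the 2-methylprop-2-en-1-yl group of compound 2 stands apart from them. Nothing measured here bears on a cause for this result.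

The compounds shown leave open whether an amine, a carboxylic acid or a plain hydrogen at this place would also leave the number within the scatter. They also leave open whether nitro would behave the same way on another carbon of the phenyl ring.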